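The source may hold more compounds than are shown below. What is called first, only, known or untested is meant among the compounds shown, and "the series" means these compounds.

Among the compounds with values here, compound 2 `O=C1c2ccccc2S(=O)(=O)N1CCCCCCN1CCN(c2cccc(Cl)c2)CC1` gives 372 nM in an ADME assay on HEK293 cells for displacement of a labelled ligand from 5-hydroxytryptamine receptor 6 (Homo sapiens), read by radioligand binding, with a stated time of 1 h (a lower number here means a stronger inhibitor, a higher number a weaker inhibitor), the lowest of the three numbers measured so far. Compound 1 `O=C1c2ccccc2S(=O)(=O)N1CCCCCCN1CCN(c2ccccc2F)CC1` gives 1620 nM, and compound 3 `O=C1c2ccccc2S(=O)(=O)N1CCCCCCN1CCN(c2cccc(Cl)c2Cl)CC1` gives 920 nM; the measured steps are a 4.4-fold lower number from compound 1 to compound 2 (0.64 log units; beyond the scatter), a 1.8-fold lower number from compound 1 to compound 3 (0.25 log units; within the scatter) and a 2.5-fold higher number from compound 2 to compound 3 (0.39 log units; beyond the scatter). Compound 4 `O=C1c2ccccc2S(=O)(=O)N1CCCCCCN1CCN(c2ccc(Cl)c(Cl)c2)CC1` is formed from compound 2 by chloro in place of hydrogen on an aromatic carbon, taking 3-chlorophenyl to 3,4-dichlorophenyl. Within the data shown here, the one measured step that adds a chloro to a 3-chlorophenyl, a 2.5-fold higher number from compound 2 to compound 3 (0.39 log units; beyond the scatter), cost a modest amount, but it is not the same change, so only a small shift toward a higher number, about the size of the scatter, is expected for compound 4, a 1.5-fold higher number from compound 2 to compound 4 (0.17 log units; within the scatter). Compound 4 is therefore estimated at 550 nM, between 200 nM and 1500 nM.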

Compound 4, inhibition constant: 132 nM
Compound 4: middle estimate off by 4.2-fold (0.62 log units), on the high side; the whole stated range lies above it.
By their numbers in this assay, from the lowest: compound 4; then compound 2; then compounds 3 and 1 (each within the scatter of the next).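

Where the added chloro sits decides the direction of the step: on the aromatic carbon ortho to a chloro group and para to a large group, it gives a 2.8-fold lower number from compound 2 to compound 4 (0.45 log units; beyond the scatter), opposite in direction to the chloro added in compound 3. With two chloro groups in both compounds, the 3,4-dichlorophenyl arrangement still gives a 7.0-fold lower number from compound 3 to compound 4 (0.84 log units; beyond the scatter), and the widest step in the set is a 12-fold lower number from compound 1 to compound 4 (1.09 log units; beyond the scatter). Nothing available here explains this dependence on position. The compounds shown leave open whether a bromo, methyl or trifluoromethyl group on that carbon would give a similar step, and whether the step would hold with a shorter chain.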